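A few compounds are considered here, and "the series" means these few. Any claim that something is new, unique, unknown or untested is made for them only; others in the source may bear on it.

Within the data shown here, in a functional assay on C6 cells (Rattus norvegicus) for cytotoxicity, read by MTT assay, with a stated time of 24 h, tested at 25 ug/mL (a lower number here means a stronger effect, a higher number a weaker effect of the compound at the concentration tested), compound 2 `Cc1ccc(-c2cs/c(=N/NC(=O)CSc3ncccn3)n2-c2ccccc2)cc1` gives 82.7%, the highest of the two numbers measured so far. Compound 1 `O=C(CSc1nnnn1-c1ccccc1)N/N=c1/scc(-c2ccc(F)cc2)n1-c1ccccc1` gives 49.3% in this assay, a number that lies lower by more than the usual scatter. Compound 3 `O=C(CSc1ncccn1)N/N=c1/scc(-c2ccc(F)cc2)n1-c1ccccc1` has not yet been measured; it differs from compound 2 by fluoro in place of methyl on an aromatic carbon. Among the measured compounds shown here, no measured pair isolates this change, so its size is uncertain. Compound 1 carries the same fluoro group and gives 49.3% in this assay. A moderate drop of a number 17.7 percentage points lower from compound 2 to compound 3 (beyond the scatter) is therefore expected. Compound 3 is expected to give about 65%, within 42% to 88%.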

Compound 3, a percentage reported as activity, at one concentration (the size of the read-out at that concentration, not a potency): 63.9%
Beside the measured number, compound 3's estimate is 1.1 percentage points above it; the range from low to high includes it.
By their numbers in this assay, from the lowest: compound 1; then compound 3; then compound 2.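

In this assay, replacing methyl with fluoro on the same core gives a number 18.8 percentage points lower from compound 2 to compound 3 (beyond the scatter), so this change alone strengthens the effect at the concentration tested. With the 4-fluorophenyl group held constant, the group on the sulfur also matters: replacing 1-phenyl-1H-tetrazol-5-yl with pyrimidin-2-yl gives a number 14.6 percentage points higher from compound 1 to compound 3 (beyond the scatter), a weaker effect. No measurement here explains either step. Still open, from the compounds shown here alone, is how a chloro group or an amine would compare at this place on the ring. Also open, going by these compounds, is whether methyl to fluoro shifts the number similarly with 1-phenyl-1H-tetrazol-5-yl on the sulfur.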